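Swapping thiazole substituents at the limit of the assay

The source may hold more compounds than are shown below. What is called first, only, known or untested is meant among the compounds shown, and "the series" means these compounds.

Measured so far:
compound 1, `CCc1c(SC)nc2nc(-c3nc(C)cs3)cn2c1C`: 50 mg/kg
compound 2, `CCc1c(OC)nc2nc(-c3nc(C)c(C)s3)cn2c1C`: > 50 mg/kg

Both compounds were tested in a functional assay on the whole organism for antagonist activity, with Rattus norvegicus as the target, at a dose of 10 mg/kg by the oral route; on this read-out higher numbers stand for an effect only at larger amounts of compound and lower numbers for an effect already at smaller amounts. For compound 2 the reading > 50 mg/kg is a limit of the assay and not a number. Compound 2 therefore stands at the limit of > 50 mg/kg in this assay, at which 1 of the 2 values shown sits. Compound 1 gives a number, while compound 2 gives only a limit, so the two readings cannot be compared as a step.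

Compound 3, `CCc1csc(-c2cn3c(C)c(CC)c(OC)nc3n2)n1`, differs from compound 2 in one place: 4-ethyl-1,3-thiazol-2-yl in place of 4,5-dimethyl-1,3-thiazol-2-yl on an aromatic carbon. For the measured compounds named here, no step between measured compounds is known, so the size of this change has no measured guide. With the same atoms joined differently, compound 3 is expected to change little in this assay, with a step that the limit leaves unreadable from compound 2 to compound 3 that is estimated to stay within the scatter. Compound 3 is expected to give about 60 mg/kg, between 25 mg/kg and 150 mg/kg, most likely again only a limit.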

Compound 3, minimum effective dose: 50 mg/kg
For compound 3 the middle estimate is 1.2-fold (0.08 log units) above the measured one; low and high end bracket the measured number.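

In this assay, the swap of 4,5-dimethyl-1,3-thiazol-2-yl for 4-ethyl-1,3-thiazol-2-yl gives a number no higher from compound 2 to compound 3 (the limit leaves the size open). So on this aromatic carbon, a group with the same atoms joined differently can yield a real reading where the earlier group on this core yielded only a limit. The size of the step cannot be read, because the value for compound 2 is a limit of the assay and not a number: the limit of > 50 mg/kg in this assay, at which 1 of the 3 values shown sits.

As far as these compounds go, how far this change really moves the minimum effective dose therefore remains open, and one pair cannot show whether the ethyl group or the loss of the second methyl group matters. Also open, from the compounds shown here alone, is what a longer chain such as propyl, or an amine, would do on the thiazole at this place.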